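Methoxy to hydroxy at the assay limit

The source may hold more compounds than are shown below. What is called first, only, known or untested is meant among the compounds shown, and "the series" means these compounds.

In a functional assay on HL-60 cells (Homo sapiens) for antiproliferative activity (on this read-out lower numbers stand for stronger inhibition and higher numbers for weaker inhibition), compound 1 `COc1cc(O)c2c(O)ccnc2c1` gives > 30000 nM as a limit of the assay, not a number. Compound 2 `COc1cc(C(F)(F)F)cc2nccc(O)c12` gives > 30000 nM as a limit too. Compound 2 therefore stands at the limit of > 30000 nM in this assay, at which 2 of the 2 values shown sit, with no number of its own. Compound 3 `Oc1ccnc2cc(C(F)(F)F)cc(O)c12` differs from compound 2 by hydrogen in place of methyl on an oxygen on an aromatic ring, methoxy to hydroxy (hydrogen in place of methyl on an oxygen on an aromatic ring). Among the measured compounds shown here, no measured pair differs in one place, so the size of such a change is not yet known. In this assay no step beyond the scatter is expected, in either direction. The expectation rests on compound 2 with its limit > 30000 nM as the only anchor. Expected here is a number no higher from compound 2 to compound 3 (the limit leaves the size open) as a rough estimate. For compound 3 the estimate is 30000 nM with an expected range from 10000 nM to 60000 nM and another limit is likely.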

Compound 3, half-maximal inhibitory concentration: > 30000 nM
Compound 3 was reported as a limit; the forecaster's own chance of this, stated with the estimate: 65%; the middle value lies on the limit itself.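

No step can be read from compound 2 or compound 1 to compound 3, all three being limits and not numbers: the limit of > 30000 nM in this assay, at which 3 of the 3 values shown sit.

Left open by the compounds shown is the size of either change, methoxy to hydroxy or trifluoromethyl in place of methoxy, on a compound that gives a number.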